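From Chloro to Acetyl: A Step Expected Within the Scatter

A few compounds are considered here, and "the series" means these few. Any claim that something is new, unique, unknown or untested is made for them only; others in the source may bear on it.

In a functional assay on A549 cells (Homo sapiens) for antiproliferative activity, read by MTT assay (a higher number here means a weaker inhibitor, a lower number a stronger inhibitor), compound 1 (`CC1(C)CCc2cc(C(=O)/C=C/c3ccc(OCc4cn(-c5ccc(Cl)cc5)nn4)cc3)c(O)cc2O1`) gives 75500 nM as its reading. Compound 2 (`CC1(C)CCc2cc(C(=O)/C=C/c3ccc(OCc4cn(-c5ccc(Br)cc5)nn4)cc3)c(O)cc2O1`) gives 80000 nM in the same test, and compound 3 (`COc1ccc(-n2cc(COc3ccc(/C=C/C(=O)c4cc5c(cc4O)OC(C)(C)CC5)cc3)nn2)c([N+](=O)[O-])c1`) gives 99500 nM there. The position of compound 1 cannot be separated from the other two: the data show a 1.1-fold higher number from compound 1 to compound 2 (0.03 log units; within the scatter) and also a 1.3-fold higher number from compound 1 to compound 3 (0.12 log units; within the scatter) between them. The remaining pair agrees, with a 1.2-fold higher number from compound 2 to compound 3 (0.09 log units; within the scatter) on record.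

Compound 4 (`CC(=O)c1ccc(-n2cc(COc3ccc(/C=C/C(=O)c4cc5c(cc4O)OC(C)(C)CC5)cc3)nn2)cc1`) has not yet been measured. It carries acetyl in place of chloro on an aromatic carbon, para to a large group, a change that reads 4-chlorophenyl to 4-acetylphenyl (acetyl in place of chloro on an aromatic carbon). Within the data shown here, no measured step makes this exact swap, so the nearest evidence comes from changes to the same aryl group. Bromo in place of chloro gave a 1.1-fold higher number from compound 1 to compound 2 (0.03 log units; within the scatter) for that pair, and 4-methoxy-2-nitrophenyl in place of 4-chlorophenyl gave a 1.3-fold higher number from compound 1 to compound 3 (0.12 log units; within the scatter) for that one. Neither step leaves the scatter, so no step beyond the scatter is expected in this assay and no direction is firmly favoured. The estimated change is a 1.1-fold higher number from compound 1 to compound 4 (0.03 log units; within the scatter) in this expectation. For compound 4 the expected value is 80000 nM with an estimated range from 45000 nM to 140000 nM for its measurement.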

Compound 4, half-maximal inhibitory concentration: 66300 nM
Compound 4: the middle estimate sits 1.2-fold (0.08 log units) above what was measured; measured number inside the range.
By their numbers in this assay, from the lowest: compounds 4, 1, 2 and 3 (each within the scatter of the next).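

In this assay, the exchange of chloro for acetyl on an aromatic carbon, para to a large group, does not separate the two compounds, with a 1.1-fold lower number from compound 1 to compound 4 (0.06 log units; within the scatter). Compound 4 also stays within the scatter of the other two compounds, with a 1.2-fold lower number from compound 2 to compound 4 (0.08 log units; within the scatter) and a 1.5-fold lower number from compound 3 to compound 4 (0.18 log units; within the scatter), so this aryl position now holds a group of 3 heavy atoms, with 1 hydrogen-bond acceptor and 1 double bond outside aromatic rings, without a reading that stands apart from those of the 4-chlorophenyl, 4-bromophenyl or 4-methoxy-2-nitrophenyl compounds. Nothing available bears on why these four readings cannot be told apart.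

The compounds shown leave open whether an amine, a carboxylic acid or a longer chain at this position would give a step beyond the scatter, since no group shown here does so. They also leave open whether a change elsewhere in the shared core, rather than on this aryl group, would move the reading in this assay at all.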